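Methylsulfonylpropoxy in place of methoxy on the head group

A few compounds are considered here, and "the series" means these few. Any claim that something is new, unique, unknown or untested is made for them only; others in the source may bear on it.

Measured so far in a functional assay on CHO cells for agonist activity at Free fatty acid receptor 1 (Homo sapiens), read by FLIPR and calcium flux; on this read-out higher numbers stand for an effect only at larger amounts of compound and lower numbers for an effect already at smaller amounts:
compound 1 `COc1cc(C)c(-c2cccc(COc3ccc(S(=O)(=O)CC(=O)O)cc3)c2)c(C)c1` gives 57.5 nM
compound 2 `COc1cc(C)c(-c2cccc(COc3ccc4c(c3)C(=O)CC4CC(=O)O)c2)c(C)c1` gives 234 nM
compound 3 `CO/N=C1\CC(CC(=O)O)c2ccc(OCc3cccc(-c4c(C)cc(OC)cc4C)c3)cc21` is reported only as a limit, > 1000 nM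

Compound 1 stands lowest of the two numbers in this assay; compound 2 sits at a higher number, beyond the scatter. The value for compound 3 is a limit of the assay rather than a number, as seen for (the limit of > 1000 nM in this assay, at which 1 of the 3 values shown sits). Compound 4 `Cc1cc(OCCCS(C)(=O)=O)cc(C)c1-c1cccc(COc2ccc(S(=O)(=O)CC(=O)O)cc2)c1` keeps everything of compound 1 except one change: 2-(methylsulfonyl)ethyl in place of hydrogen on a saturated chain carbon bound to an oxygen on an aromatic ring. Among the measured compounds shown here, no measured pair isolates this change, so the expectation rests on compound 1 alone. A modest move toward lower numbers, or none beyond the scatter, is expected: a 1.9-fold lower number from compound 1 to compound 4 (0.28 log units; within the scatter). Compound 4 is estimated at 30 nM, within 8 nM to 120 nM.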

Compound 4, half-maximal effective concentration: 170 nM
The estimate for compound 4 lay 5.7-fold (0.75 log units) below the measured number, outside the stated range (above it).
By their numbers in this assay, from the lowest: compound 1; then compounds 4 and 2 (each within the scatter of the next). At a limit, above all of these: compound 3.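

Among the compounds shown here, compounds 1 and 4 form the first pair that isolates a change on the head group: methoxy to 3-(methylsulfonyl)propoxy gives a 3.0-fold higher number from compound 1 to compound 4 (0.47 log units; beyond the scatter) in this assay. The position therefore takes this much longer chain with a modest loss, not a collapse of the effect. Nothing at hand explains the step.

Still open, from the compounds shown here alone, is whether the step follows the chain itself or its methylsulfonyl end; a plain propoxy or a 3-hydroxypropoxy group in the same place would separate the two. Also open, going by these compounds, is whether the change carries over to the core of compound 2.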